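Acylsulfonamide in place of the piperidine acid on the aryl oxygen

This account rests on a few compounds, and the source may have more. Where it says the series, first, only, none or still open, it means among the compounds named here.

Measured compounds:
- compound 1, `O=C(O)COc1ccc([C@H]2CC[C@]3(CC2)OOC2(O3)C3CC4CC(C3)CC2C4)cc1`, 2.9
- compound 2, `CCOC(=O)COc1ccc([C@H]2CC[C@]3(CC2)OOC2(O3)C3CC4CC(C3)CC2C4)cc1`, > 5.3
- compound 3, `O=C(O)CN1CCC(Oc2ccc([C@H]3CC[C@]4(CC3)OOC3(O4)C4CC5CC(C4)CC3C5)cc2)CC1`, "not determined" (no result reported)

Compound 3 stands nowhere on the numbers: in a physicochemical assay for lipophilicity, read by HPLC, at pH 7.4 (on this read-out higher numbers stand for higher lipophilicity and lower numbers for lower lipophilicity), compound 3 gives "not determined" (no result reported), so there is no value to step from. Compound 2 reports only a limit, (the limit of > 5.3 in this assay, at which 1 of the 3 values shown sits), in this assay. Among the measured compounds shown here, the one measured step, a number at least 2.40 log units higher from compound 1 to compound 2 (beyond the scatter), is the only change with a number attached.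

Compound 4, `CS(=O)(=O)NC(=O)COc1ccc([C@H]2CC[C@]3(CC2)OOC2(O3)C3CC4CC(C3)CC2C4)cc1`, arises from compound 3 by ((methylsulfonyl)carbamoyl)methyl in place of 1-(carboxymethyl)piperidin-4-yl on an oxygen on an aromatic ring. The change is not of the kind covered by the measured step, which swaps ethyl for hydrogen on an oxygen next to a carbonyl group, so that step gives no direct handle on the size or direction of the new step in this assay. Compound 4 shares its core with compound 1, and the value of compound 1 in this assay is the nearest anchor on hand. The expected value of compound 4 in this assay is 3.3, estimated to fall between 2.5 and 4.3.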

Compound 4, distribution coefficient: 3
The estimate for compound 4 lay 0.30 log units above the measured number, within the range that was stated.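

In this assay, methanesulfonamido in place of hydroxy on a carbonyl carbon gives a number 0.10 log units higher from compound 1 to compound 4 (within the scatter), so compound 1 and compound 4 read alike at this position. Methanesulfonamido in place of ethoxy on a carbonyl carbon gives a number at least 2.30 log units lower from compound 2 to compound 4 (beyond the scatter), which leaves the ethoxy compound apart from both the hydroxy and the methanesulfonamido compounds, and the read-out at this carbonyl carbon does not follow every replacement of the hydroxy group. The value of compound 2 is a limit and not a number: the limit of > 5.3 in this assay, at which 1 of the 4 values shown sits.

Steps to or from compound 3 cannot be read, so the place of the 1-(carboxymethyl)piperidin-4-yl group in this assay stays open, and with it any comparison of that group with ((methylsulfonyl)carbamoyl)methyl on an oxygen on an aromatic ring. The compounds shown also leave open how this assay would read with a longer chain in place of the methyl on the sulfonyl group, or with an amine in place of methanesulfonamido on the carbonyl carbon.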